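Replacing pentan-3-yl with a tert-butylphenyl group on the shared core

A few compounds are considered here, and "the series" means these few. Any claim that something is new, unique, unknown or untested is made for them only; others in the source may bear on it.

Three compounds sharing one core have been examined in an ADME assay for permeability, using PAMPA, with a stated time of 30 min, at pH 7.4; on this read-out lower numbers stand for lower permeability and higher numbers for higher permeability. Compound 1 `COc1ccc(F)cc1CNCCCNc1ccnc2cc(Oc3ccc(C(C)(C)C)cc3)ccc12` gives 317 10^-6 cm/s, and compound 2 `COc1ccc(F)cc1CNCCCNc1ccnc2cc(Oc3ccc(F)cc3)ccc12` gives 317 10^-6 cm/s; the step of no change at the digits printed from compound 1 to compound 2 (within the scatter) shows that these two cannot be told apart. Compound 3 `CCC(CC)c1ccc2c(NCCCNCc3cc(F)ccc3OC)ccnc2c1` gives 23 10^-6 cm/s, the lowest number of the three, and it stands well apart from both of the others, as the steps of a 14-fold lower number from compound 1 to compound 3 (1.14 log units; beyond the scatter) and a 14-fold lower number from compound 2 to compound 3 (1.14 log units; beyond the scatter) show.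

Compound 4 `COc1ccc(F)cc1CNCCCNc1ccnc2cc(-c3ccc(C(C)(C)C)cc3)ccc12` is not yet measured in this assay. It differs from compound 3 in one place, (4-(tert-butyl)phenyl in place of pentan-3-yl on an aromatic carbon). The two measured steps that bear on this change are the ones from compound 1 and compound 2 down to compound 3, where an aryl ether in that place gave way to pentan-3-yl and the number fell sharply. Going by the values given here, in compound 4 a ring returns to that place, this time joined directly rather than through oxygen, so a rise of roughly the same order is expected, with the caveat that no direct biaryl analogue has been measured here.

For compound 4 a value of 200 10^-6 cm/s is estimated, in the range 60 10^-6 cm/s to 450 10^-6 cm/s, which corresponds to an expected step of an 8.7-fold higher number from compound 3 to compound 4 (0.94 log units; beyond the scatter).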

Compound 4, apparent permeability in the ADME assay: 237 10^-6 cm/s
Compound 4: middle estimate off by 1.2-fold (0.07 log units), on the low side, within the range that was stated.
By their numbers in the ADME assay, from the lowest: compound 3; then compounds 4, 1 and 2 (each within the scatter of the next).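

The oxygen link is not needed at this place on the shared core: in the ADME assay, the steps of a 1.3-fold lower number from compound 1 to compound 4 (0.13 log units; within the scatter) and a 1.3-fold lower number from compound 2 to compound 4 (0.13 log units; within the scatter) leave the directly joined 4-(tert-butyl)phenyl group indistinguishable from the two aryl ethers. In the ADME assay, the step of a 10-fold higher number from compound 3 to compound 4 (1.01 log units; beyond the scatter) now measures this exchange directly, and among these four compounds only compound 3, the one with pentan-3-yl and no ring at this place, stands apart. In a physicochemical assay for solubility, with a stated time of 18 h, at pH 7.4 (a higher number here means a more soluble compound, a lower number a less soluble compound), compound 3 gives 4200 nM and compound 4 gives 32000 nM, so the same exchange also comes with a higher solubility number: the measured solubility of compound 3, 4200 nM, and of compound 4, 32000 nM, a 7.6-fold higher number (0.88 log units; beyond the scatter)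

Going by these compounds alone, still open is whether the higher permeability numbers follow the aromatic ring itself or simply the larger group, as pentan-3-yl is the only group without a ring here, and a cyclohexyl group at this place would separate the two. A pyridine ring joined directly, or a phenyl ring carrying a morpholine, would show how far this place tolerates nitrogen or oxygen in the incoming group.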